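The source may report more compounds than this note shows. Statements on the series, on what has been measured and on what is new or still open speak of the compounds shown alone.

Measured so far in an ADME assay on HEK-293T cells (Homo sapiens) for inhibition, read by CCK-8 assay, with a stated time of 48 h, tested at 20 uM; on this read-out lower numbers stand for less inhibition of growth and higher numbers for more inhibition of growth at the one concentration tested:
Compound 1 `COc1ccc(S(=O)(=O)Oc2ccccc2/C=C(\C#N)C(=O)Nc2nnc(Cc3cccc4ccccc34)s2)cc1` gives 29%
Compound 2 `N#C/C(=C\c1ccccc1OS(=O)(=O)c1ccc(Cl)cc1)C(=O)Nc1nnc(Cc2cccc3ccccc23)s1` gives 16%
Compound 3 `COc1ccc(S(=O)(=O)Oc2ccccc2/C=C(\C#N)C(=O)Nc2nnc(Cc3ccc(F)cc3)s2)cc1` gives 20%

In this assay, compound 3 at 20% lies within the usual scatter of both other compounds, even though those two differ from each other by more than the scatter. Compound 4 `N#C/C(=C\c1ccccc1OS(=O)(=O)c1ccc(Cl)cc1)C(=O)Nc1nnc(Cc2ccc(F)cc2)s1` is made from compound 3 by one change: chloro in place of methoxy on an aromatic carbon. In words, chloro takes the place of methoxy on an aromatic carbon, para to a large group.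

The same swap has been measured once, in a number 13 percentage points lower from compound 1 to compound 2 (beyond the scatter), a modest step beyond the scatter. That case carries naphthalen-1-yl where compound 3 carries 4-fluorophenyl. The difference between those two groups, seen in a number 9 percentage points lower from compound 1 to compound 3 (within the scatter), stays within the scatter, so the earlier swap seems a fair guide, although a single example is thin support. A similar drop, towards less inhibition of growth, is therefore expected, with the estimated step being a number 11 percentage points lower from compound 3 to compound 4 (beyond the scatter). For compound 4 the estimated value is 9%, with an expected range of 1% to 19%.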

Compound 4, percent growth inhibition at one concentration: 6%
For compound 4 the middle estimate is 3 percentage points above the measured one; low and high end bracket the measured number.
By their numbers in this assay, from the lowest: compounds 4, 2, 3 and 1 (each within the scatter of the next, the first and the last beyond it).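

In this assay the swap of methoxy for chloro, para to a large group, now has a second example, a number 14 percentage points lower from compound 3 to compound 4 (beyond the scatter), on a core carrying 4-fluorophenyl rather than naphthalen-1-yl, and its size holds: the same change on two cores in this assay, a number 13 percentage points lower (beyond the scatter) from compound 1 to compound 2 and a number 14 percentage points lower (beyond the scatter) from compound 3 to compound 4, 1 percentage points apart, within the scatter of two such steps. The other change, 4-fluorophenyl in place of naphthalen-1-yl, also repeats, with a number 10 percentage points lower from compound 2 to compound 4 (within the scatter) on the chloro pair: the same change on two cores in this assay, a number 9 percentage points lower (within the scatter) from compound 1 to compound 3 and a number 10 percentage points lower (within the scatter) from compound 2 to compound 4, 1 percentage points apart, within the scatter of two such steps. Across these four compounds, then, the chloro swap lowers inhibition of growth on both cores, whichever of the two groups sits at the far end of the molecule.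

As far as these compounds go, only methoxy and chloro appear at this place, so it remains open whether the drop follows from gaining chloro or from losing methoxy. A plain hydrogen, a fluoro or a dimethylamino group there could begin to separate the two readings.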